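This account rests on a few compounds, and the source may have more. Where it says the series, first, only, none or still open, it means among the compounds named here.

Compound 1 `COc1cc(C(c2ccc(O)c(OC)c2)[C@H](C)C(C)C)ccc1O` gives 16000 nM in a functional assay on HeLa cells (Homo sapiens) for cytotoxicity, read by WST assay, with a stated time of 48 h; on this read-out lower numbers stand for stronger inhibition and higher numbers for weaker inhibition. Compound 2 `COc1cc(C(c2ccc(O)c(OC)c2)[C@@H](CF)C(C)C)ccc1O` gives 41000 nM in this assay. Compound 3 `COC[C@@H](C)[C@@H](C)C(c1ccc(O)c(OC)c1)c1ccc(O)c(OC)c1` gives > 100000 nM in this assay.

Compound 3 stands weakest of the three measured compounds, and its value is only a limit, sitting at the limit of > 100000 nM in this assay, at which 1 of the 3 values shown sits. Compound 4 `CC[C@H](C(C)C)C(c1ccc(O)c(OC)c1)c1ccc(O)c(OC)c1` differs from compound 3 by 1-isopropylpropyl in place of 2-(methoxymethyl)-1-methylpropyl on a saturated chain carbon bound to two aromatic carbons. Among the measured compounds shown here, two measured steps bear on this change, both running toward compound 3: an at least 6.2-fold higher number from compound 1 to compound 3 (0.79 log units; beyond the scatter), and an at least 2.4-fold higher number from compound 2 to compound 3 (0.38 log units; beyond the scatter). Taking the methoxy away again is therefore expected to lower the number in this assay by a modest to large amount, though compound 4 is not identical to compound 1, so the return need not be complete. Compound 4 is expected to give 20000 nM, in the range 8000 nM to 60000 nM, which means an at least 5.0-fold lower number from compound 3 to compound 4 (0.69 log units; beyond the scatter).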

Compound 4, half-maximal inhibitory concentration: 9700 nM
The estimate for compound 4 lay 2.1-fold (0.31 log units) above the measured number; the measured number falls inside the stated range.
By their numbers in this assay, from the lowest: compounds 4 and 1 (each within the scatter of the next); then compound 2. At a limit, above all of these: compound 3.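

With 1-isopropylpropyl on the saturated chain carbon bound to two aromatic carbons, this assay shows an at least 10-fold lower number from compound 3 to compound 4 (1.01 log units; beyond the scatter), so the loss seen with 2-(methoxymethyl)-1-methylpropyl is reversed. That step rests on a limit for compound 3: the limit of > 100000 nM in this assay, at which 1 of the 4 values shown sits. The all-carbon chain also differs from the fluorinated one, with a 4.2-fold lower number from compound 2 to compound 4 (0.63 log units; beyond the scatter), while the extra methyl gives a 1.6-fold lower number from compound 1 to compound 4 (0.22 log units; within the scatter).

From the compounds shown here alone, whether a longer chain or an amine at this position would lower the number further remains open. So does how a carboxylic acid in place of the methoxy would read.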